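This account rests on a few compounds, and the source may have more. Where it says the series, first, only, none or still open, it means among the compounds named here.

Working notes on the series. Compound 1 `CCCCCCCCCCCCn1nnc(C(C(=O)Nc2ncccc2C)c2ccccc2)n1` gives 4% in an assay on isolated protein for inhibition of sterol O-acyltransferase 1 (Mus musculus), tested at 0.1 uM (a higher number here means more inhibition at the concentration tested (going by the name of the read-out), a lower number less inhibition), and compound 2 `CCCCCCCCCCCCn1nnc(C(C(=O)Nc2c(C)nn(C)c2C)c2ccccc2)n1` gives 66%. Among the measured compounds shown here, the one step measured so far, a number 62 percentage points higher from compound 1 to compound 2 (beyond the scatter), lies beyond the scatter. For the measured compounds named here, on these two numbers compound 2 stands highest; the gap to its only neighbour, compound 1, is the step just given.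

Compound 3 `CCCCCCCCCCCCn1nnc(C(C(=O)NC2CC2)c2ccccc2)n1` follows from compound 2 by a change at the same position: cyclopropyl in place of 1,3,5-trimethyl-1H-pyrazol-4-yl on an amide-type nitrogen. Going by the values given here, the only step that bears on this is a number 62 percentage points higher from compound 1 to compound 2 (beyond the scatter), which shows that the group on the amide-type nitrogen can move the read-out strongly; no step shows a non-aromatic group there. The expected step is a number 36 percentage points lower from compound 2 to compound 3 (beyond the scatter), with wide uncertainty. Compound 3 is estimated at 30%, with a range from 5% to 65%.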

Compound 3, a percentage reported as inhibition, at one concentration (the size of the read-out at that concentration, not a potency): 10%
Estimate against measurement, compound 3: 20 percentage points above; the measured number falls inside the stated range.
By their numbers in this assay, from the lowest: compounds 1 and 3 (each within the scatter of the next); then compound 2.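

Cyclopropyl on the amide-type nitrogen gives a number 56 percentage points lower from compound 2 to compound 3 (beyond the scatter) in this assay and so this non-aromatic group does not hold the level of compound 2. Set against 3-methylpyridin-2-yl, it gives a number 6 percentage points higher from compound 1 to compound 3 (within the scatter) and so an aromatic ring on this nitrogen is not enough in itself: compound 1 has one, yet among these three groups only the 1,3,5-trimethyl-1H-pyrazol-4-yl of compound 2 stands apart. No measurement at hand explains why that group stands apart.

The compounds shown do not separate the contribution of the ring nitrogens of 1,3,5-trimethyl-1H-pyrazol-4-yl from that of its methyl groups. As far as these compounds go, how a phenyl ring or an open butyl chain on the amide-type nitrogen would read also stays open.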